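A Pyrazolyl Ring for a Hydroxymethyl on Compound 2

This account rests on a few compounds, and the source may have more. Where it says the series, first, only, none or still open, it means among the compounds named here.

Three compounds sharing one core have been compared in a functional assay on CHO cells for antagonist activity at sphingosine 1-phosphate receptor 2 (Homo sapiens), read by scintillation counting and GTPgammaS binding, with a stated time of 4 h, in the presence of a further agent that is not named here; on this read-out higher numbers stand for weaker inhibition and lower numbers for stronger inhibition. Compound 1 `Cc1cc(NNC(=O)Nc2cc(Cl)nc(Cl)c2)ncc1N(C)C` gives 5.3 nM in this assay. Within the data shown here, compound 3 `Cc1cc(NNC(=O)Nc2cc(Cl)nc(Cl)c2)ncc1-c1cn(C)nc1C` gives 0.8 nM, and the one-place move a 6.6-fold lower number from compound 1 to compound 3 (0.82 log units; beyond the scatter) is the only single change among the measured set. Compound 2 `Cc1cc(CO)nc(NNC(=O)Nc2cc(Cl)nc(Cl)c2)c1` gives 31 nM, the highest of the three numbers; its gaps to compound 1 and to compound 3 both lie beyond the scatter, so compound 2 stands as the weakest of the three in this assay.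

Compound 4 `Cc1cc(NNC(=O)Nc2cc(Cl)nc(Cl)c2)nc(-c2cnn(C)c2)c1` is not yet measured. It differs from compound 2 by 1-methyl-1H-pyrazol-4-yl in place of hydroxymethyl on an aromatic carbon. Among the measured compounds shown here, no measured step repeats this replacement at this place. For the measured compounds named here, the closest precedent is a 6.6-fold lower number from compound 1 to compound 3 (0.82 log units; beyond the scatter), where a methylated pyrazolyl ring also entered for a small group, though on a different carbon and without a hydroxyl leaving. Because a 6.6-fold lower number from compound 1 to compound 3 (0.82 log units; beyond the scatter) went in the lowering direction, a lowering step is expected for compound 4 as well, and the expectation is a 3.9-fold lower number from compound 2 to compound 4 (0.59 log units; beyond the scatter), with the size less certain than the direction. Compound 4 is therefore estimated at 8 nM in this assay, within a range from 2.5 nM to 30 nM.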

Compound 4, half-maximal inhibitory concentration: 3.1 nM
Compound 4: the middle estimate sits 2.6-fold (0.41 log units) above what was measured; low and high end bracket the measured number.
By their numbers in this assay, from the lowest: compound 3; then compounds 4 and 1 (each within the scatter of the next); then compound 2.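

In this assay, among these compounds, a 10-fold lower number from compound 2 to compound 4 (1.00 log units; beyond the scatter) is the first measured step at the aromatic carbon next to the ring nitrogen. It shows that this carbon carries a 1-methyl-1H-pyrazol-4-yl group of six heavy atoms, with no hydrogen-bond donor, in place of a hydroxymethyl group of two heavy atoms, and that the number falls rather than rises with this change. Taken with a 6.6-fold lower number from compound 1 to compound 3 (0.82 log units; beyond the scatter), a methylated pyrazolyl ring has now lowered the number on two different carbons and in place of two different groups, and no step among these compounds goes against that; nothing measured here speaks to the reason for either step.

The compounds shown do not separate the departure of the hydroxymethyl group from the arrival of the ring: a methoxymethyl group, an aminomethyl group or a pyrazolyl ring without its methyl at this carbon would bear on that question. Also open, going by these compounds, is whether a carboxylic acid, a morpholine ring or a longer alkyl chain at this carbon would follow the same direction.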